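This account rests on a few compounds, and the source may have more. Where it says the series, first, only, none or still open, it means among the compounds named here.

Compound 1 `NCCCCCCOc1ccc2c(=O)c(-c3ccc(O)cc3)coc2c1` is the reference point. In an assay (Cricetulus griseus) for inhibition of aldehyde dehydrogenase, mitochondrial (Homo sapiens) (a higher number here means a weaker inhibitor, a lower number a stronger inhibitor), compound 1 gives 100 nM, the lowest of the numbers recorded, with compound 3 `O=c1c(-c2ccc(O)cc2)coc2cc(OCCCCCCCCCO)ccc12` nearest at 700 nM. Compound 2 `O=C(O)CCCCCCCCCCCCCCCOc1ccc2c(=O)c(-c3ccc(O)cc3)coc2c1` returns only a limit in this assay, > 9000 nM, which is a limit and not a number (the limit of > 9000 nM in this assay, at which 1 of the 3 values shown sits). The step to compound 4 `CC(Oc1ccc2c(=O)c(-c3ccc(O)cc3)coc2c1)C(=O)O` reads: 1-carboxyethyl in place of 6-aminohexyl on an oxygen on an aromatic ring. Going by the values given here, two measured steps bear on it. Replacing the amino end of the chain with a carboxynonyl tail gave an at least 90-fold higher number from compound 1 to compound 2 (1.95 log units; beyond the scatter), while replacing it with a hydroxypropyl end gave a 7.0-fold higher number from compound 1 to compound 3 (0.85 log units; beyond the scatter). Both changes away from the amino end of compound 1 weakened inhibition, the carboxylic acid the more so, and compound 4 both carries a carboxylic acid and shortens the chain markedly. On that basis a weakening step is expected, estimated as a 30-fold higher number from compound 1 to compound 4 (1.48 log units; beyond the scatter). Compound 4 is therefore expected to come in near 3000 nM, within a range from 500 nM to 20000 nM.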

Compound 4, half-maximal inhibitory concentration: 2500 nM
For compound 4 the middle estimate is 1.2-fold (0.08 log units) above the measured one; measured number inside the range.
By their numbers in this assay, from the lowest: compound 1; then compound 3; then compound 4. At a limit, above all of these: compound 2.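

Putting 1-carboxyethyl in place of 6-aminohexyl on the oxygen on an aromatic ring gave a 25-fold higher number from compound 1 to compound 4 (1.40 log units; beyond the scatter) in this assay. Compound 4 thus shows that a carboxylic acid on a short chain at this oxygen can still return a number, so the presence of a carboxylic acid here does not by itself lead to a limit. Compound 2, the other carboxylic acid shown, gives only a limit and not a number: the limit of > 9000 nM in this assay, at which 1 of the 4 values shown sits.

Going by these compounds, compound 4 changes the chain length and the chain end together, so what each contributes stays open, and a short chain ending in an amine or a hexyl chain ending in a carboxylic acid would bear on that. Also open, on these data alone, is whether the branch in 1-carboxyethyl matters, a question that an unbranched carboxymethyl group would address.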